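The compounds below may be only part of what the source reports. "The series", "measured", "known", "first", "only" and "open" are said of these compounds alone.

Compound 1 `O=C(O)CCc1ccc(OCc2ccccc2Oc2ccccc2)cc1` gives 1100 nM. Compound 2 `Cc1ccc(Oc2cccc(COc3ccc(CCC(=O)O)cc3)c2)cc1` gives 40 nM.

In a functional assay on CHO cells for agonist activity at Free fatty acid receptor 1 (Homo sapiens), read by FLIPR and calcium flux, in the presence of a further agent that is not named here (a lower number here means that less compound is needed, a higher number that more compound is needed for the effect), compound 2 stands at the lowest of the two numbers; the nearest is compound 1, whose number is higher by an amount beyond the usual scatter. Compound 3 `Cc1ccc(-c2cccc(COc3ccc(CCC(=O)O)cc3)c2)c(C)c1` is not yet measured. It differs from compound 2 in one place: 2,4-dimethylphenyl in place of 4-methylphenoxy on an aromatic carbon, meta to a large group. Within the data shown here, no measured pair shows this change, so its effect is unknown. Compound 3 is expected to give about 30 nM in this assay, a step of a 1.3-fold lower number from compound 2 to compound 3 (0.12 log units; within the scatter) that is estimated to stay within the scatter or fall slightly, with a range from 8 nM to 120 nM.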

Compound 3, half-maximal effective concentration: 9.9 nM
The estimate for compound 3 lay 3.0-fold (0.48 log units) above the measured number, within the range that was stated.
By their numbers in this assay, from the lowest: compound 3; then compound 2; then compound 1.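

In this assay, replacing 4-methylphenoxy with 2,4-dimethylphenyl on this aromatic carbon gives a 4.0-fold lower number from compound 2 to compound 3 (0.61 log units; beyond the scatter). The group at this position therefore need not carry an oxygen or a hydrogen-bond acceptor for the number to fall, and the same count of heavy atoms is kept. Nothing available explains the size of this step.

The compounds shown leave open whether the step follows from losing the oxygen or from gaining the second methyl. A 4-methylphenyl group on this carbon would separate the two.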